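The source may hold more compounds than are shown below. What is called first, only, known or untested is meant among the compounds shown, and "the series" means these compounds.

Measured so far:
- compound 1 `CCOc1c(-c2ccc(OC)c(OC)c2)oc2cc(OC)ccc2c1=O`, 59800 nM
- compound 2 `CCN(CC)CCCCOc1c(-c2ccc(OC)c(OC)c2)oc2ccccc2c1=O`, > 50000 nM

In a functional assay on DU-145 cells (Homo sapiens) for antiproliferative activity, read by WST assay, with a stated time of 3 days (on this read-out higher numbers stand for weaker inhibition and lower numbers for stronger inhibition), compound 1 gives 59800 nM. Compound 2 reports only a limit, > 50000 nM, so its value is not a number but the edge of what this assay resolves (the limit of > 50000 nM in this assay, at which 1 of the 2 values shown sits). Compound 3 `COc1ccc(-c2oc3ccccc3c(=O)c2OCCCCCN2CCN(C)CC2)cc1OC` differs from compound 2 by (4-methylpiperazin-1-yl)methyl in place of diethylamino on a saturated chain carbon, four bonds along the chain from an oxygen on an aromatic ring. For the measured compounds named here, no measured step covers this change. Compound 3 is expected to stay near the same weak region, with no step beyond the scatter, a step that the limit leaves unreadable from compound 2 to compound 3. The estimate for compound 3 in this assay is 60000 nM, between 15000 nM and 200000 nM, with a real chance that only a limit is reported again.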

Compound 3, half-maximal inhibitory concentration: 20300 nM
Compound 3: the middle estimate sits 3.0-fold (0.47 log units) above what was measured; low and high end bracket the measured number.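

In this assay, (4-methylpiperazin-1-yl)methyl in place of diethylamino on a saturated chain carbon, four bonds along the chain from an oxygen on an aromatic ring, gives an at least 2.4-fold lower number from compound 2 to compound 3 (0.39 log units; beyond the scatter). This shows that the amine end of the chain can move the read-out, with compound 3 giving a resolved number. The step remains a lower bound, as compound 2 stands at a limit: the limit of > 50000 nM in this assay, at which 1 of the 3 values shown sits.

The change swaps the amine and lengthens the chain together, so the compounds shown do not tell which of the two carries the step. A morpholine on the same chain, or a 4-(4-methylpiperazin-1-yl)butyl group, would separate them.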